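The source may hold more compounds than are shown below. What is called first, only, known or untested is meant among the compounds shown, and "the series" means these compounds.

In a functional assay on the whole organism with Mus musculus as the target (on this read-out higher numbers stand for an effect only at larger amounts of compound and lower numbers for an effect already at smaller amounts), compound 1 `NC(=O)Cn1c(-c2ccc(Br)cc2)nc2cccnc21` gives 17.8 mg/kg and compound 2 `CCCN(C)C(=O)Cn1c(-c2ccc(Cl)cc2)nc2cccnc21` gives 11.6 mg/kg, so compound 2 stands within the scatter of compound 1. Compound 3 `O=C(Cn1c(-c2ccc(Cl)cc2)nc2cccnc21)Nc1ccccn1` has (pyridin-2-yl)amino in place of methyl(propyl)amino on a carbonyl carbon. For the measured compounds named here, no measured pair isolates a single change, so nothing yet scales this one. In this assay no step beyond the scatter is expected, and neither direction is favoured. The estimated step is a 1.1-fold higher number from compound 2 to compound 3 (0.05 log units; within the scatter). For compound 3 the expected value is 13 mg/kg, with an estimated range from 5 mg/kg to 32 mg/kg.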

Compound 3, dose for half-maximal effect: 100 mg/kg
Estimate against measurement, compound 3: 7.7-fold (0.89 log units) below, and the stated range ends below it.
By their numbers in this assay, from the lowest: compounds 2 and 1 (each within the scatter of the next); then compound 3.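

For the compounds shown here, on the carbonyl carbon, the amide substituent matters in this assay: (pyridin-2-yl)amino in place of methyl(propyl)amino gives an 8.6-fold higher number from compound 2 to compound 3 (0.94 log units; beyond the scatter) and is the first single-place step, lying beyond the scatter towards effect only at larger amounts. The change brings in a six-membered aromatic ring, a hydrogen-bond donor and a hydrogen-bond acceptor together, so this step cannot separate them. No supporting data explain the step.

Open, as far as these compounds go, is whether phenylamino, which lacks the pyridine nitrogen, follows compound 3 or compound 2. Also open, from the compounds shown here alone, is whether a saturated ring amine such as piperidin-1-yl on the same carbonyl carbon stays with compound 2.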